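Glycine transporter inhibitors: varying the aryl carbonyl substituent

The source may report more compounds than this note shows. Statements on the series, on what has been measured and on what is new or still open speak of the compounds shown alone.

Measured compounds:
compound 1 `O=C(CN(C(=O)c1ccc(Cl)cc1)C1CCCCC1)Nc1cc(F)cc(F)c1`, 631 nM
compound 2 `O=C(CN(Cc1ccc(Cl)cc1)C1CCCCC1)Nc1cc(F)cc(F)c1`, > 25100 nM
compound 3 `CN1CCC(C(=O)N(CC(=O)Nc2cc(F)cc(F)c2)C2CCCCC2)CC1`, > 25100 nM

Among the compounds with values here, in an assay on HEK293 cells for inhibition of sodium- and chloride-dependent glycine transporter 1 (Homo sapiens), read by scintillation proximity assay (a higher number here means a weaker inhibitor, a lower number a stronger inhibitor), compound 1 gives 631 nM, the only number measured. Compound 2 is reported only as a limit of the assay, > 25100 nM. Compound 3 likewise sits at a limit, > 25100 nM; two of the three values therefore rest on (the limit of > 25100 nM in this assay, at which 2 of the 3 values shown sit). Both measured steps leave compound 1: an at least 39-fold higher number from compound 1 to compound 2 (1.59 log units; beyond the scatter), and an at least 39-fold higher number from compound 1 to compound 3 (1.59 log units; beyond the scatter). The step between compound 2 and compound 3 is a step that the two limits leave unreadable from compound 2 to compound 3.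

Compound 4 `O=C(CN(C(=O)c1ccc(-n2ccnc2)cc1)C1CCCCC1)Nc1cc(F)cc(F)c1` keeps the (4-chlorophenyl)carbonyl framework of compound 1 and alters only the substituent on the aryl ring: 1H-imidazol-1-yl in place of chloro on an aromatic carbon. Neither measured step touches this position; both remove or replace the aryl carbonyl itself and both are large losses, so they show only that the aryl carbonyl is needed, not how its substituent may be varied. Within the data shown here, no step on the aryl substituent is available, so the expectation for compound 4 is wide. In this assay compound 4 is estimated at 1600 nM (range 300 nM to 8000 nM), a step of a 2.5-fold higher number from compound 1 to compound 4 (0.40 log units; beyond the scatter) that is expected to be modest and toward a weaker inhibitor.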

Compound 4, half-maximal inhibitory concentration: 631 nM
Compound 4: the middle estimate sits 2.5-fold (0.40 log units) above what was measured; measured number inside the range.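

In this assay, the aryl substituent proves open to substantial variation, with no change at the digits printed from compound 1 to compound 4 (within the scatter) when 1H-imidazol-1-yl replaces chloro. The earlier steps shown here showed only that removing or replacing the aryl carbonyl costs activity; this one shows that, on this aromatic carbon, a single chlorine and a five-membered aromatic ring with 5 heavy atoms and 2 hydrogen-bond acceptors can read alike while the aryl carbonyl stays in place. Nothing shown here speaks to the reason for this match.

With only these two substituents at this position, the compounds shown leave open whether a carboxylic acid, a primary amine or a phenyl ring on the same carbon would also read alike. Also open, as far as these compounds go, is whether 1H-imidazol-1-yl would give the same reading on another carbon of this ring.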